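Pyrrolidin-1-yl for Benzyloxy: Expected Solubility of Compound 4

The compounds below may be only part of what the source reports. "The series", "measured", "known", "first", "only" and "open" are said of these compounds alone.

Compound 3 `COc1ccc2[nH]c(C(=O)N3CC(=O)N(Cc4ccccc4)[C@@H](COCc4ccccc4)C3)cc2c1` holds the lowest of the two plain numbers shown: in a physicochemical assay for solubility, read by spectrophotometry, in phosphate buffer, with a stated time of 2 h, at pH 7.4 (a lower number here means a less soluble compound, a higher number a more soluble compound), compound 3 gives 8800 nM. Its nearest neighbour is compound 1 `COc1ccc2[nH]c(C(=O)N3CC(=O)N(Cc4ccccc4)[C@@H](COc4ccccc4)C3)cc2c1`, which in this assay gives 12200 nM, and a 1.4-fold lower number from compound 1 to compound 3 (0.14 log units; within the scatter). Compound 2 `COc1ccc2[nH]c(C(=O)N3CC(=O)N(Cc4ccccc4)[C@@H](CN4CCCCC4)C3)cc2c1` carries piperidin-1-yl in the same place. For compound 2 the this assay reports only a limit, > 25000 nM.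

Compound 4 `COc1ccc2[nH]c(C(=O)N3CC(=O)N(Cc4ccccc4)[C@@H](CN4CCCC4)C3)cc2c1` is not yet measured. It differs from compound 3 in one place: pyrrolidin-1-yl in place of benzyloxy on a saturated chain carbon bound to a saturated ring carbon. For the measured compounds named here, two measured steps bear on this change. First, an at least 2.0-fold higher number from compound 1 to compound 2 (0.31 log units; beyond the scatter). Second, an at least 2.8-fold lower number from compound 2 to compound 3 (0.45 log units; beyond the scatter). Both steps point the same way: the saturated nitrogen ring in that position gave the higher number, and in each case the higher value was the limit of > 25000 nM in this assay, at which 1 of the 3 values shown sits.

Since pyrrolidin-1-yl is a close relative of piperidin-1-yl, a rise beyond the scatter is expected because an at least 2.8-fold lower number from compound 2 to compound 3 (0.45 log units; beyond the scatter) is run here in reverse. Compound 4 is therefore estimated at 25000 nM, with a range from 10000 nM to 70000 nM, and the expected step is a 2.8-fold higher number from compound 3 to compound 4 (0.45 log units; beyond the scatter). It is expected that the this assay may again return only a limit for compound 4.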

Compound 4, solubility: > 25000 nM
Compound 4 was reported as a limit; the forecaster's own chance of this, stated with the estimate: 60%; the middle value sits exactly at the limit.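

In this assay, pyrrolidin-1-yl on a saturated chain carbon bound to a saturated ring carbon gives an at least 2.8-fold higher number from compound 3 to compound 4 (0.45 log units; beyond the scatter), and against the phenoxy compound it gives an at least 2.0-fold higher number from compound 1 to compound 4 (0.31 log units; beyond the scatter). Until now only piperidin-1-yl had shown such a rise at this place, so the rise is no longer tied to one ring: among the four compounds shown, both saturated nitrogen rings give limits, while the phenoxy and benzyloxy compounds give plain numbers. The limit also sets how far the comparison goes, and the step between the two nitrogen-ring compounds, compound 2 and compound 4, cannot be read, so this position says nothing yet about five-membered against six-membered rings: the limit of > 25000 nM in this assay, at which 2 of the 4 values shown sit.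

Going by these compounds, how far the true values of compound 2 and compound 4 lie past this limit stays open, and so the full size of the steps to them does too. Also open, on these data alone, is whether morpholin-4-yl, or an open-chain amine such as dimethylamino, would reach the same limit on this chain carbon.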